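From a Branched Chain to an Acetylcyclohexylmethyl Group

A few compounds are considered here, and "the series" means these few. Any claim that something is new, unique, unknown or untested is made for them only; others in the source may bear on it.

Compound 3 `CCCC(CCC)n1c(-c2ccc(OCc3c(-c4c(Cl)cccc4Cl)noc3C(C)C)cc2)nc2ccc(C(=O)O)cc21` gives 1.8 nM in an assay on Huh-7 cells for agonist activity at Bile acid receptor (Homo sapiens), read by a luciferase reporter (a higher number here means that more compound is needed for the effect, a lower number that less compound is needed), the second highest of three numbers. Compound 1 `CCC(CC)n1c(-c2ccc(OCc3c(-c4c(Cl)cccc4Cl)noc3C(C)C)cc2F)nc2ccc(C(=O)O)cc21` gives 1.3 nM, a gap to compound 3 that lies within the scatter, while compound 2 `CC(C)c1onc(-c2c(Cl)cccc2Cl)c1COc1ccc(-c2nc3ccc(C(=O)O)cc3n2CC2CCCCC2)c(F)c1` gives 7.8 nM, beyond the scatter above compound 3. Compound 4 `CC(=O)C1CCC(Cn2c(-c3ccc(OCc4c(-c5c(Cl)cccc5Cl)noc4C(C)C)cc3)nc3ccc(C(=O)O)cc32)CC1` carries (4-acetylcyclohexyl)methyl in place of 1-propylbutyl on an aromatic nitrogen. Within the data shown here, the one measured step that bears on this change is a 6.0-fold higher number from compound 1 to compound 2 (0.78 log units; beyond the scatter), where a cyclohexylmethyl group likewise replaced a branched chain on an aromatic nitrogen. On that basis a modest rise in number is expected for compound 4, estimated as a 5.0-fold higher number from compound 3 to compound 4 (0.70 log units; beyond the scatter). Compound 4 is therefore expected to give 9 nM in this assay, with a range from 3 nM to 30 nM.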

Compound 4, half-maximal effective concentration: 1170 nM
Compound 4: the middle estimate sits 130-fold (2.11 log units) below what was measured, and the stated range ends below it.
By their numbers in this assay, from the lowest: compounds 1 and 3 (each within the scatter of the next); then compound 2; then compound 4.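

On an aromatic nitrogen of the shared core, replacing 1-propylbutyl with (4-acetylcyclohexyl)methyl proved far more costly than the earlier ring-bearing change: in this assay the record shows a 650-fold higher number from compound 3 to compound 4 (2.81 log units; beyond the scatter) against a 6.0-fold higher number from compound 1 to compound 2 (0.78 log units; beyond the scatter) for cyclohexylmethyl in place of pentan-3-yl. This position therefore does not treat all cyclohexyl-containing groups alike. Nothing measured here accounts for the size of this loss. The compounds shown leave open whether the acetyl group itself carries the loss. They also leave open whether a hydroxyl or an amine on the cyclohexane ring would fare better.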